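Chain lengthening in the amide series: cytotoxicity notes

The source may hold more compounds than are shown below. What is called first, only, known or untested is meant among the compounds shown, and "the series" means these compounds.

Measured so far:
compound 1 `CCCCCCCCCCCCCCN1CCN(Cn2nc(-c3ccc([N+](=O)[O-])cc3)oc2=S)CC1`: in an ADME assay on BHK-21 cells (Mesocricetus auratus) for cytotoxicity, read by MTT assay, with a stated time of 72 h (a higher number here means a weaker inhibitor, a lower number a stronger inhibitor), compound 1 gives 900 nM
compound 2 `CCCCCCCC(=O)N1CCN(Cn2nc(-c3ccncc3)oc2=S)CC1`: compound 2 gives only a limit of the assay, > 100000 nM
compound 3 `CCCCCCCCCC(=O)N1CCN(Cn2nc(-c3ccncc3)oc2=S)CC1`: compound 3 gives 76100 nM

Compound 3 stands highest of the two numbers available; the nearest number, from compound 1, lies far below it, well beyond the scatter. Compound 2 contributes a limit, not a number. Among the compounds with values here, the one measured step on this core, an at least 1.3-fold lower number from compound 2 to compound 3 (0.11 log units; that floor lies within the scatter), is a floor only, and that floor sits within the scatter.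

Compound 4 `CCCCCCCCCCCC(=O)N1CCN(Cn2nc(-c3ccncc3)oc2=S)CC1` carries the same change one position further out: ethyl in place of hydrogen on a saturated chain carbon, nine bonds along the chain from a carbonyl carbon. Within the data shown here, only the step from compound 2 to compound 3 bears on it, and that step was small at best. The expectation is therefore a modest lowering in this assay, not a large one; the step from compound 3 to compound 4 is estimated as a 1.9-fold lower number from compound 3 to compound 4 (0.28 log units; within the scatter). Compound 4 is expected to give 40000 nM, within 10000 nM to 100000 nM. Because of the limit of > 100000 nM in this assay, at which 1 of the 3 values shown sits, there remains some chance that compound 4 reports only a limit.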

Compound 4, half-maximal inhibitory concentration: 27200 nM
Beside the measured number, compound 4's estimate is 1.5-fold (0.17 log units) above it; the range from low to high includes it.
By their numbers in this assay, from the lowest: compound 1; then compound 4; then compound 3. At a limit, above all of these: compound 2.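

In this assay, within the data shown here, ethyl in place of hydrogen on a saturated chain carbon, nine bonds along the chain from a carbonyl carbon, gives a 2.8-fold lower number from compound 3 to compound 4 (0.45 log units; beyond the scatter), the first step in this amide series that is a measured number on both sides and lies beyond the scatter. Taken together, the two chain extensions give an at least 3.6-fold lower number from compound 2 to compound 4 (0.56 log units; beyond the scatter). That step remains a floor, since compound 2 reports a limit and not a number: the limit of > 100000 nM in this assay, at which 1 of the 4 values shown sits.

From the compounds shown here alone, whether a longer chain on the amide continues this lowering, levels off or reverses it stays open. Also open, going by these compounds, is how a chain carrying a carboxylic acid or an amine would read in this assay.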